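Removing a methoxy group from a benzamide-type mGlu5 modulator

A few compounds are considered here, and "the series" means these few. Any claim that something is new, unique, unknown or untested is made for them only; others in the source may bear on it.

Measured compounds:
- compound 1, `COc1cccc(C(=O)Nc2ccc(Cl)cc2CN2C(=O)c3ccccc3C2=O)c1`: 1500 nM
- compound 2, `O=C(/C=C/c1cc(Cl)ccc1NC(=O)c1ccccn1)c1ccccc1`: 1700 nM

Two compounds have been characterised in an assay on CHO cells for positive allosteric modulation of metabotropic glutamate receptor 5 (Homo sapiens), read by FLIPR; a lower number here means that less compound is needed, a higher number that more compound is needed for the effect. Compound 1 gives 1500 nM in this assay, and compound 2 gives 1700 nM. Compound 1 carries the lowest of the two numbers, but its nearest neighbour, compound 2, sits so close that the two values fall within the scatter of repeated measurement, so neither can be called the more potent of the pair.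

The step under consideration leads from compound 1 to compound 3, `O=C(Nc1ccc(Cl)cc1CN1C(=O)c2ccccc2C1=O)c1ccccc1`, which has not yet been measured in this assay. The change is hydrogen in place of methoxy on an aromatic carbon, meta to a large group, so that the (3-methoxyphenyl)carbonyl of compound 1 becomes a plain benzoyl in compound 3.

Within the data shown here, no measured pair in this set shows the effect of such a change, so the expectation rests on compound 1 alone. Because compound 1 stands at 1500 nM, a small loss of potency, or none beyond the scatter, is expected. Compound 3 is therefore estimated at 2500 nM in this assay, within 800 nM to 8000 nM, which means an expected step of a 1.7-fold higher number from compound 1 to compound 3 (0.22 log units; within the scatter).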

Compound 3, half-maximal effective concentration: > 100000 nM
Compound 3 was reported as a limit; the forecaster's own chance of this, stated with the estimate: 15%; middle value at least 40-fold (1.60 log units) from the limit.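

The methoxy group on this aromatic carbon, meta to a large group, proves far from incidental to the core of compound 1: in this assay, hydrogen in its place gives an at least 66-fold higher number from compound 1 to compound 3 (1.82 log units; beyond the scatter). The result for compound 3 is a limit and not a number: the limit of > 100000 nM in this assay, at which 1 of the 3 values shown sits. Before this result, nothing showed that a change of only two heavy atoms could matter so much here, and compound 2, which differs from compound 1 in more than one place, adds nothing on this point.

Among these compounds, the single step cannot show whether the effect belongs to the methoxy group in particular or whether another group on the same carbon, such as a methyl, an ethoxy, a hydroxyl or a fluorine, would restore the effect seen with compound 1. Nor can it show whether a methoxy group on another carbon of the same ring would serve equally well, or whether the benzamide end of the core would respond in the same way to other changes.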